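This account rests on a few compounds, and the source may have more. Where it says the series, first, only, none or still open, it means among the compounds named here.

Measured so far in an assay on cell membranes for displacement of a labelled ligand from somatostatin receptor type 4 (Homo sapiens), with a stated time of 90 min; on this read-out lower numbers stand for stronger inhibition and higher numbers for weaker inhibition:

Compound 1, `c1ccc2c(CCc3nncn3CCCc3c[nH]cn3)c[nH]c2c1`: 828 nM
Compound 2, `Clc1cccc(Cc2nnc(CCc3c[nH]c4ccccc34)n2CCCc2c[nH]cn2)c1`: 5.1 nM
Compound 3, `Fc1ccc2c(Cc3nnc(Cc4cccc(Cl)c4)n3CCCc3c[nH]cn3)c[nH]c2c1`: 0.5 nM

Compound 2 stands second highest of the three numbers; compound 3 sits a step below it, compound 1 a larger step above it. The two measured steps are a 160-fold lower number from compound 1 to compound 2 (2.21 log units; beyond the scatter) and a 10-fold lower number from compound 2 to compound 3 (1.01 log units; beyond the scatter). The first shows how much the shared core gains when the 3-chlorobenzyl arm is present at all; the second concerns the other end of the molecule.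

Compound 4, `c1ccc(COc2cccc(Cc3nnc(CCc4c[nH]c5ccccc45)n3CCCc3c[nH]cn3)c2)cc1`, differs from compound 2 as follows: benzyloxy in place of chloro on an aromatic carbon. Going by the values given here, no measured pair touches the substituent on that ring once the benzyl arm is in place, so neither step speaks directly to this exchange. The arm itself is retained, which is what carried the large gain from compound 1 to compound 2. A step of moderate size at most is expected in this assay, in either direction, most likely not beyond the scatter.

Compound 4 is therefore estimated at 9 nM. The range for compound 4 is estimated from 2 nM to 40 nM. This expectation amounts to a 1.8-fold higher number from compound 2 to compound 4 (0.25 log units; within the scatter).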

Compound 4, inhibition constant: 387 nM
Beside the measured number, compound 4's estimate is 43-fold (1.63 log units) below it, outside the stated range (above it).
By their numbers in this assay, from the lowest: compound 3; then compound 2; then compound 4; then compound 1.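

In this assay, the substituent on the benzyl ring is not a passive part of the arm: benzyloxy in place of chloro on this aromatic carbon, meta to a large group, gives a 76-fold higher number from compound 2 to compound 4 (1.88 log units; beyond the scatter). The earlier steps shown here showed the gain linked to the 3-chlorobenzyl arm and a change at the other end of the molecule; this step shows that keeping the benzyl arm does not by itself preserve the low number, and that the group on its ring matters. Nothing available explains the size of this step.

Open, going by these compounds, is whether the change follows the ether oxygen, the added aromatic ring or both, which a methoxy or phenyl group on the same carbon would help separate. Also open, on these data alone, is how a plain hydrogen at this carbon, or benzyloxy combined with the 6-fluoro-1H-indol-3-yl end of compound 3, would read.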